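Expected loss of agonist potency on N-methylation of compound 2

The source may report more compounds than this note shows. Statements on the series, on what has been measured and on what is new or still open speak of the compounds shown alone.

Compound 2 `CC(C)Oc1cncc(C2=CC3CNCC(C2)C3)c1` sits in the middle of the three compounds measured in an in vitro functional assay on SH-EP1 cells for agonist activity at Neuronal acetylcholine receptor; alpha4/beta2 (Homo sapiens), read by FLIPR and calcium flux; on this read-out lower numbers stand for an effect already at smaller amounts and higher numbers for an effect only at larger amounts of compound. Its value of 164 nM is the second highest of the three: compound 3 `COc1cncc(C2=CC3CNCC(C2)C3)c1` gives 49 nM, and the step from one to the other is a 3.3-fold lower number from compound 2 to compound 3 (0.52 log units; beyond the scatter), a change at the aryl ether. Compound 1 `COc1cncc(C2=CC3CC(C2)CN(C)C3)c1` gives 2660 nM, the highest number of the set. Within the data shown here, the step from compound 1 to compound 3 is a 54-fold lower number from compound 1 to compound 3 (1.73 log units; beyond the scatter), the sole step in the set that touches the ring amine.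

Compound 4 `CC(C)Oc1cncc(C2=CC3CC(C2)CN(C)C3)c1` differs from compound 2 by methyl in place of hydrogen on an amine nitrogen in a ring. This is the reverse of the change between compound 1 and compound 3, where removing the methyl from the ring nitrogen gave a large drop in the number. Taken in the opposite direction, the step from compound 2 to compound 4 is therefore expected to be a large rise in this assay, and a 43-fold higher number from compound 2 to compound 4 (1.63 log units; beyond the scatter) is the estimate. Because the step of a 54-fold lower number from compound 1 to compound 3 (1.73 log units; beyond the scatter) was so large, compound 4 is expected to give about 7000 nM, with a plausible range from 2000 nM to 25000 nM; compound 2 and compound 3 show that the isopropyl ether already raises the number, which adds to this expectation.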

Compound 4, half-maximal effective concentration: > 10000 nM
Compound 4: only a limit was reported (the forecaster's own chance of this, stated with the estimate: 15%); middle value at least 1.4-fold (0.15 log units) from the limit.
By their numbers in this assay, from the lowest: compound 3; then compound 2; then compound 1. At a limit, above all of these: compound 4.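

In this assay compound 4 gives > 10000 nM, which is a limit of the assay and not a number. Methyl in place of hydrogen on the amine nitrogen in the ring, until now read only on the methyl ether, also carries a large penalty on the isopropyl ether, with an at least 60-fold higher number from compound 2 to compound 4 (1.78 log units; beyond the scatter), so the change holds on both cores shown: the same change on two cores in this assay, a 54-fold lower number (1.73 log units; beyond the scatter) from compound 1 to compound 3 and an at least 60-fold lower number (1.78 log units; beyond the scatter) from compound 4 to compound 2; the limit leaves it open whether they differ. Isopropyl in place of methyl on the oxygen, until now read only with hydrogen on the ring nitrogen, also goes the same way with a methyl there, with an at least 3.7-fold higher number from compound 1 to compound 4 (0.57 log units; beyond the scatter), so neither change cancels the other in these four compounds: the same change on two cores in this assay, a 3.3-fold lower number (0.52 log units; beyond the scatter) from compound 2 to compound 3 and an at least 3.7-fold lower number (0.57 log units; beyond the scatter) from compound 4 to compound 1; the limit leaves it open whether they differ.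

The limit leaves open how far compound 4 really lies from the others, and so whether the two changes simply add or reinforce each other. The compounds shown also leave open how an ethyl group on the ring nitrogen, or an ethyl group or a longer chain on the oxygen, would read in this assay.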